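Hydroxy addition on the chalcone series: RAW264.7 cytotoxicity notes

The source may hold more compounds than are shown below. What is called first, only, known or untested is meant among the compounds shown, and "the series" means these compounds.

Measured compounds:
compound 1 `COc1ccc(/C=C/C(=O)c2ccc(OC)c(OC)c2)cc1` — 73.9%
compound 2 `COc1cc(C(=O)CCc2cccc(OC)c2OC)ccc1O` — 90.5%
compound 3 `COc1cccc(/C=C/C(=O)c2cccc(O)c2)c1OC` — 32.8%

In an ADME assay on RAW264.7 cells (Mus musculus) for cytotoxicity, read by MTT assay, with a stated time of 24 h, tested at 10 ug/mL (a higher number here means a weaker effect of the compound at the concentration tested, a lower number a stronger effect), compound 1 gives 73.9%, the second highest of the three numbers. Its nearest neighbour is compound 2 with 90.5%, a gap beyond the scatter; the furthest is compound 3 with 32.8%, also beyond the scatter. Compound 1 thus sits toward the weaker end of the range, closer to compound 2 than to compound 3.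

Compound 4 `COc1ccc(/C=C/C(=O)c2ccc(OC)c(OC)c2)cc1O` is not yet measured in this assay. It differs from compound 1 in one place: hydroxy in place of hydrogen on an aromatic carbon. The new group enters ortho to a methoxy group and meta to a large group, on the ring that already carries a methoxy group in compound 1.

Among the measured compounds shown here, no pair of measured compounds shares this exact change, so no measured step guides the estimate. Compound 2, which carries a hydroxy ortho to a methoxy group on its own core, gives 90.5%, the highest number in the set, while compound 3 with a hydroxy on the other ring gives 32.8%. On this thin basis the expected step from compound 1 to compound 4 is small and upward, a number 6.1 percentage points higher from compound 1 to compound 4 (within the scatter), likely within or just at the scatter. Compound 4 is therefore estimated at 80%, with a range of 62% to 95%.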

Compound 4, a percentage reported as activity, at one concentration (the size of the read-out at that concentration, not a potency): 73.5%
Estimate against measurement, compound 4: 6.5 percentage points above; the measured number falls inside the stated range.
By their numbers in this assay, from the lowest: compound 3; then compounds 4 and 1 (each within the scatter of the next); then compound 2.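

In this assay hydroxy in place of hydrogen on an aromatic carbon, ortho to a methoxy group and meta to a large group, gives a number 0.4 percentage points lower from compound 1 to compound 4 (within the scatter) and thus no readable effect of this change at this position on the core of compound 1. Among the compounds shown here, this is the first step that isolates a single change: compound 2 and compound 3 also carry a hydroxy, but each differs from compound 1 in more than one place, so their numbers could not show what the hydroxy alone does. Nothing measured here on any property of these compounds bears on this result.

From the compounds shown here alone, what an amine, a carboxylic acid or a longer chain would give at this same position stays open, as does whether hydroxy in place of hydrogen at other positions on the shared core would also stay within the scatter. Going by these compounds, the read-out comes from one concentration, so how compound 1 and compound 4 would compare across a range of concentrations also remains open.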